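From hydroxyphenyl to piperidine on a shared core

A few compounds are considered here, and "the series" means these few. Any claim that something is new, unique, unknown or untested is made for them only; others in the source may bear on it.

Three measured compounds share one core and differ only in the group attached to it. Compound 1 `c1ccc(-c2nc(-c3c[nH]c4ccccc34)co2)cc1` carries a plain phenyl; in a functional assay on MCF7 cells (Homo sapiens) for cytotoxicity, read by MTT assay, with a stated time of 48 h (on this read-out higher numbers stand for weaker inhibition and lower numbers for stronger inhibition), compound 1 gives 131000 nM. Compound 2 `Oc1ccc(-c2nc(-c3c[nH]c4ccccc34)co2)cc1` carries a hydroxy group on that phenyl, and in this assay compound 2 gives 580000 nM, a step of a 4.4-fold higher number from compound 1 to compound 2 (0.65 log units; beyond the scatter). Compound 3 `COc1cc(-c2nc(-c3c[nH]c4ccccc34)co2)ccc1O` adds a methoxy group beside the hydroxy, and in this assay compound 3 gives 103000 nM, a step of a 5.6-fold lower number from compound 2 to compound 3 (0.75 log units; beyond the scatter). Compound 2 therefore has the highest number of the three, meaning the weakest inhibition; both other compounds lie beyond the scatter from it.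

Compound 4 `c1ccc2c(-c3coc(C4CCNCC4)n3)c[nH]c2c1` is not yet measured. It differs from compound 2 by piperidin-4-yl in place of 4-hydroxyphenyl on an aromatic carbon. Among the measured compounds shown here, neither measured step bears directly on this change: both alter substituents on the phenyl rather than exchanging the whole ring, so the data give no direct precedent for the size or direction of the step. The measured range is narrow, so the expectation is that compound 4 stays in that range. Compound 4 is estimated at 250000 nM, within 60000 nM to 900000 nM. This estimate implies an expected step of a 2.3-fold lower number from compound 2 to compound 4 (0.37 log units; beyond the scatter).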

Compound 4, half-maximal inhibitory concentration: 295000 nM
The estimate for compound 4 lay 1.2-fold (0.07 log units) below the measured number; the measured number falls inside the stated range.
By their numbers in this assay, from the lowest: compounds 3 and 1 (each within the scatter of the next); then compounds 4 and 2 (each within the scatter of the next).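

The result shows that this position, on an aromatic carbon of a five-membered aromatic ring with 1 nitrogen and 1 oxygen, accepts more than changes on the phenyl: the whole aromatic ring can be exchanged for a non-aromatic one with a ring nitrogen. In this assay the move to piperidin-4-yl in place of 4-hydroxyphenyl gives a 2.0-fold lower number from compound 2 to compound 4 (0.29 log units; within the scatter) and so leaves compound 2 and compound 4 indistinguishable, whereas the move to piperidin-4-yl in place of plain phenyl gives a 2.3-fold higher number from compound 1 to compound 4 (0.35 log units; beyond the scatter) and is a real but modest loss of inhibition. Which ring does better therefore depends on the phenyl it is compared with, and no measurement here explains either step.

The compounds shown leave open whether the ring nitrogen of the piperidine matters at all, a question that cyclohexyl, which has only carbon in the ring, or an N-methylpiperidin-4-yl group could test. They also leave open whether a ring is needed here, or whether an open chain ending in an amine or a carboxylic acid would serve on the same carbon of the shared core.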